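The source may report more compounds than this note shows. Statements on the series, on what has been measured and on what is new or still open speak of the compounds shown alone.

Measured so far in a functional assay on LOX IMVI cells (Homo sapiens) for inhibition; a higher number here means a weaker inhibitor of growth, a lower number a stronger inhibitor of growth:
- compound 1 `C=C1C(=O)O[C@H]2[C@H]1CC/C(COC(=O)N1CCC(F)(F)CC1)=C\CC[C@@]1(C)O[C@@H]21`: 2230 nM
- compound 2 `C=C1C(=O)O[C@H]2[C@H]1CC/C(COC(=O)NCCN1CCCC1)=C\CC[C@@]1(C)O[C@@H]21`: 7880 nM

Of the two measured compounds, compound 2 has the higher number, at 7880 nM, so it is the weaker inhibitor of growth in this assay. Its nearest neighbour is compound 1 at 2230 nM.

The next compound is compound 3 `C=C1C(=O)O[C@H]2[C@H]1CC/C(COC(=O)Nc1n[nH]c(SC)n1)=C\CC[C@@]1(C)O[C@@H]21`, which keeps the shared core and the carbonyl. The change is 5-(methylsulfanyl)-1H-1,2,4-triazol-3-yl in place of 2-(pyrrolidin-1-yl)ethyl on an amide-type nitrogen.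

Among the measured compounds shown here, only one measured step bears on this: a 3.5-fold higher number from compound 1 to compound 2 (0.55 log units; beyond the scatter). It is modest, and it involves the same group that compound 3 gives up. For the measured compounds named here, no measured compound carries the incoming triazolyl group, so the direction rests on thin evidence. Compound 2 sits at the high end of the two numbers at 7880 nM, so a modest step toward a lower number is expected, of similar size to the measured one. The expected step is a 2.8-fold lower number from compound 2 to compound 3 (0.45 log units; beyond the scatter). Compound 3 is estimated at 2800 nM, with an expected range of 900 nM to 8000 nM.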

Compound 3, concentration for 50% growth inhibition: 1950 nM
Estimate against measurement, compound 3: 1.4-fold (0.16 log units) above; the measured number falls inside the stated range.
By their numbers in this assay, from the lowest: compounds 3 and 1 (each within the scatter of the next); then compound 2.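

Among the compounds shown here, on the amide-type nitrogen, 5-(methylsulfanyl)-1H-1,2,4-triazol-3-yl in place of 2-(pyrrolidin-1-yl)ethyl gives a 4.0-fold lower number from compound 2 to compound 3 (0.61 log units; beyond the scatter) in this assay, the first step in which that nitrogen stays and only its substituent changes, and this change alone moves the number beyond the scatter. Exchanging 4,4-difluoropiperidin-1-yl on the carbonyl carbon for (5-(methylsulfanyl)-1H-1,2,4-triazol-3-yl)amino gives a 1.1-fold lower number from compound 1 to compound 3 (0.06 log units; within the scatter), so two quite different groups give numbers that cannot be told apart, and among the three only the compound carrying 2-(pyrrolidin-1-yl)ethyl stands apart. Nothing available on these compounds offers an explanation for this pattern.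

On these data alone, it remains open whether the higher number seen with 2-(pyrrolidin-1-yl)ethyl goes with the pyrrolidine ring or with the ethyl chain, which a 2-(piperidin-1-yl)ethyl group or a plain butyl chain on the same nitrogen could help separate. As far as these compounds go, the share of the methylsulfanyl group in the triazole result is also open, and the unsubstituted 1H-1,2,4-triazol-3-yl group or a methoxy group in its place would bear on that.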